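From methoxymethyl to ethoxy on an aromatic carbon

This account rests on a few compounds, and the source may have more. Where it says the series, first, only, none or still open, it means among the compounds named here.

Going by the values given here, in a physicochemical assay for solubility, at pH 6.5 (a lower number here means a less soluble compound, a higher number a more soluble compound), compound 1 (`COCc1nc2nc(C)cc(Nc3ccc(C(F)(F)F)cc3)n2n1`) gives 150000 nM and stands highest of the two numbers so far. Compound 2 (`COCCc1nc2nc(C)cc(Nc3ccc(S(F)(F)(F)(F)F)cc3)n2n1`) gives 31000 nM in the same measurement, a gap beyond the scatter. Compound 2 differs from compound 1 in more than one place, however, so that gap cannot be tied to any single change.

Compound 3 (`CCOc1nc2nc(C)cc(Nc3ccc(C(F)(F)F)cc3)n2n1`) has not yet been measured. It carries ethoxy in place of methoxymethyl on an aromatic carbon, between two ring nitrogen atoms, with the same atoms joined differently (ethoxy in place of methoxymethyl on an aromatic carbon). Among the compounds with values here, no measured pair isolates this swap, so the expectation rests on the structural change alone and remains uncertain. In this assay a small downward step is expected, probably within the scatter. The expected step is a 1.7-fold lower number from compound 1 to compound 3 (0.22 log units; within the scatter) on this estimate. Compound 3 is estimated at 90000 nM with a wide range (35000 nM to 220000 nM).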

Compound 3, solubility: 19000 nM
Estimate against measurement, compound 3: 4.7-fold (0.68 log units) above; measured number outside the range, below it.
By their numbers in this assay, from the lowest: compounds 3 and 2 (each within the scatter of the next); then compound 1.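

Going by these compounds alone, compound 2 differs from compound 1 in more than one place, so only this pair shows what the position does: with the rest of compound 1 kept, ethoxy in place of methoxymethyl on the aromatic carbon between two ring nitrogen atoms gives a 7.9-fold lower number from compound 1 to compound 3 (0.90 log units; beyond the scatter) in this assay. The two groups have the same atoms and the same counts of heavy atoms, hydrogen-bond donors and hydrogen-bond acceptors, and neither carries a net charge, so these counts do not separate them, and the way the atoms are joined at this position is the only difference between the two compounds. Nothing measured here bears on why the rearrangement is followed by a step of this size.

Going by these compounds, this is a single pair, on a core carrying trifluoromethyl, so it remains open whether the swap would give a step of similar size with another group in that place. On these data alone, it is also open where a longer chain such as propoxy, or an amine, on this aromatic carbon would stand relative to ethoxy and methoxymethyl.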